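A Fluorine Swap on a Hydrazone Antiproliferative Scaffold

This account rests on a few compounds, and the source may have more. Where it says the series, first, only, none or still open, it means among the compounds named here.

Compound 1 `C/C(=N\NC(=O)c1cccc(S(=O)(=O)N2CCOCC2)c1)c1cccc(N)c1` was examined in a functional assay on EC9706 cells (Homo sapiens) for antiproliferative activity, read by MTT assay, with a stated time of 72 h; on this read-out higher numbers stand for weaker inhibition and lower numbers for stronger inhibition. In this assay compound 1 reaches only > 100000 nM, which is a limit of the assay rather than a measured number. Compound 2 `C/C(=N\NC(=O)c1cccc(S(=O)(=O)N2CCOCC2)c1)c1cc(Br)ccc1O` differs from compound 1 in one place, and in this assay compound 2 gives 24700 nM. Going by the values given here, the step of an at least 4.0-fold lower number from compound 1 to compound 2 (0.60 log units; beyond the scatter) is the only measured comparison available, and its true size is uncertain because compound 1 sits at the limit of > 100000 nM in this assay, at which 1 of the 2 values shown sits. Compound 3 `C/C(=N\NC(=O)c1cccc(S(=O)(=O)N2CCOCC2)c1)c1cc(F)ccc1O` carries the change (5-fluoro-2-hydroxyphenyl in place of 3-aminophenyl on a carbon with a double bond to nitrogen). Among the compounds with values here, this change closely resembles the one from compound 1 to compound 2, with fluorine standing where bromine stood, so a step in the same direction is expected, though its size could be somewhat smaller. For compound 3 the expected step is an at least 2.5-fold lower number from compound 1 to compound 3 (0.39 log units; beyond the scatter). Compound 3 is therefore estimated at 40000 nM in this assay, with a range from 12000 nM to 150000 nM.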

Compound 3, half-maximal inhibitory concentration: 2210 nM
Compound 3: middle estimate off by 18-fold (1.26 log units), on the high side; measured number below the stated range.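

Exchanging the bromo of compound 2 for fluoro gives an 11-fold lower number from compound 2 to compound 3 (1.05 log units; beyond the scatter) in this assay, so with the 2-hydroxyphenyl part kept, the choice of halogen alone strongly changes the read-out. Going by these compounds alone, the earlier pair could not show this, since its one step changed the whole group on the carbon with a double bond to nitrogen. The step of an at least 45-fold lower number from compound 1 to compound 3 (1.65 log units; beyond the scatter) is large, but its full size cannot be read because compound 1 stands at a limit of the assay, not at a number: the limit of > 100000 nM in this assay, at which 1 of the 3 values shown sits.

On these data alone, two halogens do not make a trend, so how a chloro group or a plain hydrogen in place of the fluoro would compare remains open. As far as these compounds go, it also remains open whether the hydroxy group matters, which a methoxy group in its place could test.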